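Swapping the Aryl Group on the Ring Amine Nitrogen

The source may hold more compounds than are shown below. What is called first, only, known or untested is meant among the compounds shown, and "the series" means these compounds.

Three compounds share one core and differ only in the group on an amine nitrogen in a ring. In a functional assay on CHO cells with adenosine receptor A1 (Homo sapiens) as the target, read by cAMP accumulation and immunoassay, with a stated time of 6 min, tested at 10 uM (a higher number here means a weaker effect of the compound at the concentration tested, a lower number a stronger effect), compound 1 `CC(C)N1CCN(Cc2csc(N)c2C(=O)c2ccc(Cl)cc2)CC1` gives -7.4%, compound 2 `Nc1scc(CN2CCN(c3cc(Cl)cc(Cl)c3)CC2)c1C(=O)c1ccc(Cl)cc1` gives -74%, and compound 3 `COc1ccc(N2CCN(Cc3csc(N)c3C(=O)c3ccc(Cl)cc3)CC2)cc1` gives -52%. Compound 3 thus stands second highest of the three, nearest to compound 2 and furthest from compound 1. The steps show that an aryl group in that position lowers the number strongly: a number 66.6 percentage points lower from compound 1 to compound 2 (beyond the scatter) and a number 44.6 percentage points lower from compound 1 to compound 3 (beyond the scatter). Between the two aryl groups the difference is modest: a number 22 percentage points higher from compound 2 to compound 3 (beyond the scatter).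

Compound 4 `Nc1scc(CN2CCN(c3cccc(C(F)(F)F)c3)CC2)c1C(=O)c1ccc(Cl)cc1` carries a third aryl group: 3-(trifluoromethyl)phenyl in place of 4-methoxyphenyl on an amine nitrogen in a ring. Going by the values given here, the steps that bear on this change are the large drop from compound 1 to compound 3 and the modest rise from compound 2 to compound 3, both beyond the scatter, which put the two aryl compounds within a modest span of each other. Compound 4 is therefore expected to fall in that same region, with a number 10 percentage points lower from compound 3 to compound 4 (within the scatter) as a modest step downward. In this assay compound 4 is estimated at -62%, in a range from -85% to -35%.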

Compound 4, a percentage reported as activity, at one concentration (the size of the read-out at that concentration, not a potency): -80%
For compound 4 the middle estimate is 18 percentage points above the measured one, and the stated range covers the measured number.
By their numbers in this assay, from the lowest: compounds 4 and 2 (each within the scatter of the next); then compound 3; then compound 1.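

In this assay, the aryl groups on this ring nitrogen proved not to be interchangeable: 3-(trifluoromethyl)phenyl in place of 4-methoxyphenyl gave a further clear shift (a number 28 percentage points lower from compound 3 to compound 4 (beyond the scatter)), so the earlier modest gap between compound 2 and compound 3 was no isolated case. The 3-(trifluoromethyl)phenyl and 3,5-dichlorophenyl groups could not be told apart (a number 6 percentage points lower from compound 2 to compound 4 (within the scatter)), and compound 3 stands apart from both of them, while the replacement of isopropyl by 3-(trifluoromethyl)phenyl gave a large step (a number 72.6 percentage points lower from compound 1 to compound 4 (beyond the scatter)), the third aryl group confirming that all of those shown lie well below the isopropyl compound. No measurement at hand accounts for these differences between the groups.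

The compounds shown leave open whether the separation of compound 3 follows from the methoxy group itself or from where it sits on the phenyl ring, since the substituents and their places change together in this set. They also leave open how the read-out would respond to a nitrile or a carboxylic acid on the phenyl ring, or to a longer chain such as benzyl in place of the directly attached aryl group.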